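The source may report more compounds than this note shows. Statements on the series, on what has been measured and on what is new or still open speak of the compounds shown alone.

Compound 1 `CCCCOc1ccc(C(CC(=O)O)c2ccccc2)cc1` has the lowest of the two numbers in a functional assay on HEK293 cells for agonist activity at Free fatty acid receptor 1 (Homo sapiens), read by calcium flux; a higher number here means that more compound is needed for the effect, a lower number that less compound is needed: compound 1 gives 1.2 uM, while compound 2 `CCCCCOc1ccc(C(CC(=O)O)c2ccccc2)cc1` gives 2.97 uM, a step of a 2.5-fold higher number from compound 1 to compound 2 (0.39 log units; beyond the scatter). Compound 3 `CCCCOc1ccc(C(CCCC(=O)O)c2ccccc2)cc1` differs from compound 1 by 2-carboxyethyl in place of carboxy on a saturated chain carbon, two bonds along the chain from two aromatic carbons. Going by the values given here, the only measured step concerns the chain on the other side of the shared core, so no measured step bears directly on this change. The acid is moved two bonds further from the core, and a weaker effect is expected, the step being a 5.0-fold higher number from compound 1 to compound 3 (0.70 log units; beyond the scatter). Compound 3 is thus estimated at 6 uM, within 1.5 uM to 25 uM.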

Compound 3, concentration for half-maximal effect: > 10 uM
Compound 3: only a limit was reported; the forecaster's own chance of this, stated with the estimate: 10%; middle value at least 1.6-fold (0.22 log units) away from the limit.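

Lengthening the carboxy-bearing chain, with 2-carboxyethyl in place of carboxy on this saturated chain carbon, gives an at least 8.3-fold higher number from compound 1 to compound 3 (0.92 log units; beyond the scatter). So this position, unlike the ether chain changed in compound 2, has now been tested directly, and the longer acid chain does not hold the level of compound 1. In this assay, compound 3 gives > 10 uM, which is a limit and not a number.

The compounds shown leave open how the number changes with a 3-carboxypropyl group's shorter neighbour, a propanoic acid chain holding a single added carbon. They also leave open whether an amide could stand in place of the carboxylic acid.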